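This account rests on a few compounds, and the source may have more. Where it says the series, first, only, none or still open, it means among the compounds named here.

Series notes. Compound 1 `CCN(c1ccc(C#N)c(Cl)c1)c1cc(-c2cnc3ccccc3c2)ccc1C` has "not determined" (no result reported) in a functional assay on CWR22R cells (Homo sapiens) for antiproliferative activity, read by CCK-8 assay, with a stated time of 6 days; a higher number here means a weaker inhibitor, a lower number a stronger inhibitor. Compound 3 `Cc1noc(C)c1-c1cccc2c1CCCN2c1ccc(C#N)c(C(F)(F)F)c1` likewise has "not determined" (no result reported) in this assay. Compound 2 `CCN(c1ccc(C#N)c(Cl)c1)c1cc(-c2cncnc2)ccc1C` gives only the assay limit > 30000 nM in this assay, not a number. So compound 2 stands at the limit (the limit of > 30000 nM in this assay, at which 1 of the 3 values shown sits), and no single value exists among the three entries shown; no step between measured compounds can be read. Compound 4 `CCN(c1ccc(C#N)c(Cl)c1)c1cc(-c2cn[nH]c2)ccc1C` differs from compound 2 by 1H-pyrazol-4-yl in place of pyrimidin-5-yl on an aromatic carbon. With compound 2 at the limit, the step from compound 2 to compound 4 in this assay is expected to stay small, an at least 1.2-fold lower number from compound 2 to compound 4 (0.07 log units; that floor lies within the scatter), with a fair chance that only a limit is again reported. Compound 4 is estimated at 25000 nM, in the range 6000 nM to 80000 nM.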

Compound 4, half-maximal inhibitory concentration: > 30000 nM
Compound 4: a limit, no number; the forecaster's own chance of this, stated with the estimate: 55%; middle value at least 1.2-fold (0.07 log units) from the limit.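

The step from compound 2 to compound 4 cannot be read in this assay, since both entries are limits, not numbers: the limit of > 30000 nM in this assay, at which 2 of the 4 values shown sit. The compounds shown leave open whether any other group in that place gives a single number in this assay.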